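The compounds below may be only part of what the source reports. "The series", "measured", "known", "first", "only" and "open" are said of these compounds alone.

The compounds measured in a functional assay on A549 cells (Homo sapiens) for cytotoxicity, read by sulforhodamine B assay, with a stated time of 72 h (on this read-out lower numbers stand for stronger inhibition and higher numbers for weaker inhibition), are:

Compound 1 `Cc1c(-c2csc(/N=c3\sc(-c4ccccc4)nn3-c3ccccc3)n2)c(=O)n(-c2ccccc2)n1C` — > 100000 nM
Compound 2 `CC(=O)c1nn(-c2ccccc2)/c(=N/c2nc(-c3c(C)n(C)n(-c4ccccc4)c3=O)cs2)s1` — > 100000 nM
Compound 3 `CCOC(=O)c1nn(-c2ccccc2)/c(=N/c2nc(-c3c(C)n(C)n(-c4ccccc4)c3=O)cs2)s1` — > 100000 nM

Each of these three values is a limit of the assay and not a number. Compound 3 stands at that limit, and so do compound 1 and compound 2, which is the whole of what is known here: the limit of > 100000 nM in this assay, at which 3 of the 3 values shown sit. The steps among the measured compounds, a step that the two limits leave unreadable from compound 1 to compound 2, a step that the two limits leave unreadable from compound 1 to compound 3 and a step that the two limits leave unreadable from compound 2 to compound 3, are therefore all unreadable in size and direction.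

Compound 4 `CCOC(=O)c1nn(-c2ccc(OC)cc2)/c(=N/c2nc(-c3c(C)n(C)n(-c4ccccc4)c3=O)cs2)s1` differs from compound 3 in one place: methoxy in place of hydrogen on an aromatic carbon. Going by the values given here, none of the measured steps touches this phenyl ring, and none of them is readable, so no measured step gives a size for this change in this assay. With all three shown compounds at the limit, compound 4 is expected to sit at the limit as well, so the estimated step that the limit leaves unreadable from compound 3 to compound 4 is none beyond the scatter. For compound 4 the estimate in this assay is 200000 nM, with a range from 60000 nM to 1000000 nM.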

Compound 4, half-maximal inhibitory concentration: 13100 nM
Estimate against measurement, compound 4: 15-fold (1.18 log units) above; measured number outside the range, below it.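

Methoxy on the phenyl ring, para to a large group, gives the first readable step in this assay: an at least 7.6-fold lower number from compound 3 to compound 4 (0.88 log units; beyond the scatter). Going by these compounds alone, the steps among compound 1, compound 2 and compound 3 cannot be read, so this phenyl to 4-methoxyphenyl change is the first to show that the series can leave the limit, and compound 4 is the only compound here with a number: the limit of > 100000 nM in this assay, at which 3 of the 4 values shown sit. Compound 3 has a limit and not a number, > 100000 nM, so the step gives only a lower bound on the size of this change.

The compounds shown leave open whether a chlorine, a hydroxyl or an ethoxy group at this place would give a similar number. They also leave open whether methoxy would lift compound 1 or compound 2 off the limit, with phenyl or acetyl in place of the ethoxycarbonyl group of compound 4.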